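This account rests on a few compounds, and the source may have more. Where it says the series, first, only, none or still open, it means among the compounds named here.

In an ADME assay on microsomes (Mus musculus) for metabolic stability, with a stated time of 1 h, tested at 1 uM (on this read-out higher numbers stand for a more stable compound and lower numbers for a less stable compound), compound 1 `C[C@@H]1CN([C@H](C)CO)C(=O)c2cccc(NC(=O)c3ccncc3)c2O[C@H]1CN(C)Cc1ccc(Oc2ccccc2)cc1` gives 1%. Compound 2 `C[C@@H]1CN([C@@H](C)CO)C(=O)c2cccc(NC(=O)c3ccncc3)c2O[C@@H]1CN(C)Cc1ccc(Oc2ccccc2)cc1` gives < 1%, which is a limit of the assay and not a number, and it stands at that limit (the limit of < 1% in this assay, at which 1 of the 2 values shown sits). Compound 3 `C[C@@H]1CN([C@@H](C)CO)C(=O)c2cccc(NC(=O)c3ccncc3)c2O[C@H]1CN(C)Cc1ccc(Oc2ccccc2)cc1` differs from compound 2 thus: the two compounds have the same atoms and bonds and differ only in configuration as drawn: 1 of 3 stereo elements differ; a stereocentre at a saturated ring carbon is drawn S in compound 2 and R in compound 3. For the measured compounds named here, the one measured step bearing on this, a number no higher from compound 1 to compound 2 (the limit leaves the size open), is also purely a change of configuration (the fact that compounds 1 and 2 differ only in the configuration as drawn), and its size stays open. Going by the values given here, with that step as the only guide, no change beyond the scatter is expected. The expected step of a number no lower from compound 2 to compound 3 (the limit leaves the size open) is therefore small. Compound 3 is estimated at 1%, with an expected range of 0% to 5%.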

Compound 3, percent of the compound remaining: 2%
Compound 3: middle estimate off by 1 percentage points, on the low side; low and high end bracket the measured number.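

In this assay, the change at the saturated ring carbon alone reads a number at least 1 percentage points higher from compound 2 to compound 3 (that floor lies within the scatter), and the change at the saturated chain carbon alone reads a number 1 percentage points higher from compound 1 to compound 3 (within the scatter). The earlier pair differed at both centres together, whereas each centre is now seen changing alone, and neither step shows a change beyond the scatter. Both comparisons isolate configuration: the fact that compounds 1 and 3 differ only in the configuration as drawn

From the compounds shown here alone, the stereocentre shared unchanged by all three compounds remains untested. Also open, going by these compounds, is whether a group such as an amine or a longer chain, in place of the hydroxyl-bearing chain, would alter the percent remaining.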